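The source may hold more compounds than are shown below. What is called first, only, known or untested is meant among the compounds shown, and "the series" means these compounds.

Measured compounds:
compound 1 `COc1ccc2nc(-c3ccc(N/C=C\C(=O)c4cc(OC)c(OC)c(OC)c4)cc3)sc2c1` gives 19600 nM
compound 2 `COc1cc(OC)c2sc(-c3ccc(N/C=C\C(=O)c4cc(OC)c(OC)c(OC)c4)cc3)nc2c1` gives 15800 nM
compound 3 `COc1ccc2nc(-c3ccc(N/C=C\C(=O)c4cc(OC)c(OC)c(OC)c4Br)cc3)sc2c1` gives 11100 nM

All three numbers come from a functional assay on MDA-MB-231 cells (Homo sapiens) for antiproliferative activity, read by sulforhodamine B assay, with a stated time of 48 h; a lower number here means a stronger inhibitor, a higher number a weaker inhibitor. Compound 1 and compound 3 differ by one change, (bromo in place of hydrogen on an aromatic carbon); the step is a 1.8-fold lower number from compound 1 to compound 3 (0.25 log units; within the scatter). The difference between the core of compound 1 and the core of compound 2 is not broken down here; in this assay compound 1 and compound 2 give numbers within the scatter of each other.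

Compound 4 `COc1cc(OC)c2sc(-c3ccc(N/C=C\C(=O)c4cc(OC)c(OC)c(OC)c4Br)cc3)nc2c1` is not yet measured. It differs from compound 2 by bromo in place of hydrogen on an aromatic carbon, the same change as from compound 1 to compound 3, at a place described in the same words. The expected step is a 1.8-fold lower number from compound 2 to compound 4 (0.24 log units; within the scatter), resting on the measured step from compound 1 to compound 3 of a 1.8-fold lower number from compound 1 to compound 3 (0.25 log units; within the scatter) applied to the value of compound 2. For compound 4 the estimate in this assay is 9000 nM, expected to fall between 4000 nM and 20000 nM.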

Compound 4, half-maximal inhibitory concentration: 16100 nM
Estimate against measurement, compound 4: 1.8-fold (0.25 log units) below, within the range that was stated.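

In this assay, bromo in place of hydrogen on an aromatic carbon gives a 1.0-fold higher number from compound 2 to compound 4 (0.01 log units; within the scatter), and setting this beside the earlier step does not separate the two cores: the same change on two cores in this assay, a 1.8-fold lower number (0.25 log units; within the scatter) from compound 1 to compound 3 and a 1.0-fold higher number (0.01 log units; within the scatter) from compound 2 to compound 4, 1.8-fold (0.26 log units) apart, within the scatter of two such steps

As far as these two pairs go, the change carries from one core to the other without a step beyond the scatter on either core. They do not show that the change acts identically on both cores, or that bromo would be without effect in other compounds or assays.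

From the compounds shown here alone, what fluoro, methyl or an amine would do at this aromatic carbon remains open. Also open, going by these compounds, is whether any such group would give a step beyond the scatter on either core.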